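Swapping a bicyclic amide side group for a single pyrazole

This account rests on a few compounds, and the source may have more. Where it says the series, first, only, none or still open, it means among the compounds named here.

Measured so far:
- Compound 1 `CCOc1ncc(-c2nc(C(F)(F)F)sc2N2CCN(C(=O)Cn3ccc4cnccc43)[C@H](C)C2)cn1` gives 23 nM
- Compound 2 `CCOc1ncc(-c2nc(C(F)(F)F)sc2N2CCN(C(=O)Cn3ncc4cccnc43)[C@H](C)C2)cn1` gives 55 nM
- Compound 3 `CCOc1ncc(-c2nc(C(F)(F)F)sc2N2CCN(C(=O)Cn3c(=O)oc4ccccc43)[C@H](C)C2)cn1` gives 99 nM

All three share one core and differ only in the aromatic group attached to the saturated chain carbon bound to the carbonyl carbon. In a functional assay on U2OS cells for antagonist activity at C-X-C chemokine receptor type 3 (Homo sapiens), read by beta-arrestin recruitment (a lower number here means a stronger inhibitor, a higher number a weaker inhibitor), compound 3 has the highest number of the three, meaning the weakest inhibition. Its gap to compound 2 is small, a 1.8-fold higher number from compound 2 to compound 3 (0.26 log units; within the scatter), while the gap to compound 1 is larger, a 4.3-fold higher number from compound 1 to compound 3 (0.63 log units; beyond the scatter).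

Compound 4 `CCOc1ncc(-c2nc(C(F)(F)F)sc2N2CCN(C(=O)Cn3nccc3C)[C@H](C)C2)cn1` carries the change (a group of 6 heavy atoms (4 carbon, 2 nitrogen; one five-membered aromatic ring with 2 hetero atoms) in place of a group of 10 heavy atoms (7 carbon, 1 nitrogen, 2 oxygen; one five-membered aromatic ring with 2 hetero atoms, one six-membered aromatic ring of carbon only), on a saturated chain carbon bound to a carbonyl carbon). Within the data shown here, every measured step so far, including a 2.4-fold higher number from compound 1 to compound 2 (0.38 log units; beyond the scatter), exchanged one two-ring group for another and moved the number only modestly. None of them removed the second ring entirely, as this change does, so the measured steps bear on it only loosely: they show that this position tolerates variation without large swings. The expectation for this assay is therefore a step from compound 3 to compound 4 that is small, most likely a slight rise, a 1.5-fold higher number from compound 3 to compound 4 (0.18 log units; within the scatter), with wide uncertainty. Compound 4 is estimated at 150 nM, ranging from 40 nM to 600 nM.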

Compound 4, half-maximal inhibitory concentration: 162 nM
Estimate against measurement, compound 4: 1.1-fold (0.03 log units) below; the measured number falls inside the stated range.
By their numbers in this assay, from the lowest: compound 1; then compounds 2, 3 and 4 (each within the scatter of the next, the first and the last beyond it).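

In this assay, the group that leaves carries a six-membered aromatic ring of carbon only, and putting 5-methyl-1H-pyrazol-1-yl in its place gives a 1.6-fold higher number from compound 3 to compound 4 (0.21 log units; within the scatter) and so no readable loss at this saturated chain carbon bound to a carbonyl carbon. Among these compounds, the earlier steps only traded one two-ring group for another, so this is the first sign that the second ring can go entirely without a readable cost, at least against compound 3. The single ring does fall short of the other two-ring groups, with a 2.9-fold higher number from compound 2 to compound 4 (0.47 log units; beyond the scatter) and a 7.0-fold higher number from compound 1 to compound 4 (0.85 log units; beyond the scatter) as steps that both lie beyond the scatter, so two rings can beat one here, although compound 3 goes against any such rule.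

Still open, going by these compounds, is whether a plain pyrazol-1-yl, or a pyrazole with an ethyl or a trifluoromethyl group in place of the methyl, would come closer to compound 1 at this carbon. Nothing at hand explains the differences among these numbers.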